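Methyl in place of oxolan-3-yl on compound 3

The source may hold more compounds than are shown below. What is called first, only, known or untested is meant among the compounds shown, and "the series" means these compounds.

In an ADME assay on MDCK cells (Canis lupus familiaris) for permeability, read by LC-MS, with a stated time of 90 min, tested at 2 uM (a lower number here means that the compound crosses the layer more slowly, a higher number that the compound crosses the layer faster), compound 1 (`COC(c1cc(Cl)c2c(c1Cl)C(=O)N(Cc1c(C)cc(C)[nH]c1=O)CC2)C1CCOCC1`) gives 13.3 10^-6 cm/s; 16.5 10^-6 cm/s (2 entries) and compound 2 (`Cc1cc(C)c(CN2CCc3c(Cl)cc(C(CO)c4ccon4)c(Cl)c3C2=O)c(=O)[nH]1`) gives 5.8 10^-6 cm/s; 8.6 10^-6 cm/s (2 entries) over two entries each. For the measured compounds named here, compound 3 (`Cc1cc(C)c(CN2CCc3c(Cl)cc([C@@H](CO)[C@@H]4CCOC4)c(Cl)c3C2=O)c(=O)[nH]1`) gives 3 10^-6 cm/s as its only number, clearly under compound 1, while two further entries yield no single number. Compound 4 (`Cc1cc(C)c(CN2CCc3c(Cl)cc([C@H](C)CO)c(Cl)c3C2=O)c(=O)[nH]1`) carries methyl in place of oxolan-3-yl on a saturated chain carbon bound to an aromatic carbon and a saturated chain carbon. Going by the values given here, no measured pair shows this change alone. The expectation therefore takes compound 2 at 5.8 10^-6 cm/s; 8.6 10^-6 cm/s (2 entries) as its nearest guide. A modest rise is expected (a 2.3-fold higher number from compound 3 to compound 4 (0.37 log units; beyond the scatter)) that only just clears the scatter. The estimated value for compound 4 is 7 10^-6 cm/s (range 3 10^-6 cm/s to 15 10^-6 cm/s).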

Compound 4, apparent permeability: 12.4 10^-6 cm/s
Beside the measured number, compound 4's estimate is 1.8-fold (0.25 log units) below it, and the stated range covers the measured number.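

In this assay, methyl in place of oxolan-3-yl on this saturated chain carbon gives a 4.1-fold higher number from compound 3 to compound 4 (0.62 log units; beyond the scatter), the first change in one place alone among these compounds. For the compounds shown here, that step is wider than the gap between repeat entries of a single compound: the several entries of compound 2 in this assay, 5.8 10^-6 cm/s; 8.6 10^-6 cm/s (2 entries) Compound 3 contributes only one number to the step, 3 10^-6 cm/s.

The compounds shown do not separate loss of the ring from loss of its oxygen. On these data alone, whether a cyclopentyl ring or an ethyl chain at this carbon would read closer to compound 3 or compound 4 remains open.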